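A few compounds are considered here, and "the series" means these few. Any claim that something is new, unique, unknown or untested is made for them only; others in the source may bear on it.

Compound 1 `O=C(/C=C\Nc1ccc(F)cc1)c1cn(-c2ccccc2)nc1-c1ccc(Cl)cc1` carries a fluoro group on the ring attached to the nitrogen; in a functional assay on HT-29 cells (Homo sapiens) for antiproliferative activity, read by MTT assay, with a stated time of 48 h (on this read-out lower numbers stand for stronger inhibition and higher numbers for weaker inhibition), compound 1 reaches only the limit > 50000 nM, which is a limit of the measurement and not a number. Compound 2 `O=C(/C=C\Nc1ccc(Cl)cc1)c1cn(-c2ccccc2)nc1-c1ccc(Cl)cc1` differs from compound 1 in its core by fluoro in place of chloro on an aromatic carbon, and in this assay compound 2 gives 4650 nM, a step of an at least 10-fold lower number from compound 1 to compound 2 (1.03 log units; beyond the scatter). Compound 3 `COc1ccc(N/C=C\C(=O)c2cn(-c3ccccc3)nc2-c2ccc(Cl)cc2)cc1` gives 8930 nM, which against compound 1 is an at least 5.5-fold lower number from compound 1 to compound 3 (0.74 log units; beyond the scatter). Between compound 2 and compound 3 the change is methoxy in place of chloro on an aromatic carbon, and the step is a 1.9-fold higher number from compound 2 to compound 3 (0.28 log units; within the scatter). Compound 4 `COc1ccc(-c2nn(-c3ccccc3)cc2C(=O)/C=C\Nc2ccc(F)cc2)cc1` is not yet measured; it differs from compound 1 by methoxy in place of chloro on an aromatic carbon, the same kind of change, but here the reading one bond further out is only 4-chlorophenyl to 4-methoxyphenyl, so it sits on a different ring than in compound 3. Because compound 1 stands at the limit of > 50000 nM in this assay, at which 1 of the 3 values shown sits, and because the step of a 1.9-fold higher number from compound 2 to compound 3 (0.28 log units; within the scatter) was small, a step that the limit leaves unreadable from compound 1 to compound 4 is expected, and compound 4 is estimated at 60000 nM, between 15000 nM and 250000 nM.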

Compound 4, half-maximal inhibitory concentration: 7650 nM
The estimate for compound 4 lay 7.8-fold (0.89 log units) above the measured number, and the stated range ends above it.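

In this assay, methoxy in place of chloro, here 4-chlorophenyl to 4-methoxyphenyl, gives an at least 6.5-fold lower number from compound 1 to compound 4 (0.81 log units; beyond the scatter), so this change does not carry over with the same size from one core to the other: the same change on two cores in this assay, a 1.9-fold higher number (0.28 log units; within the scatter) from compound 2 to compound 3 and an at least 6.5-fold lower number (0.81 log units; beyond the scatter) from compound 1 to compound 4, at least 12-fold (1.09 log units) apart, beyond the scatter of two such steps. Neither the step nor the gap between the two steps has a known full size, and each is only a lower bound, since the starting value for compound 4 is a limit of the measurement and not a number: the limit of > 50000 nM in this assay, at which 1 of the 4 values shown sits. These two pairs show that the result of this change depends on where it is made in this series, but they do not show why, and they cannot predict its size on a further core.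

On these data alone, it remains open whether methoxy in place of chloro would give a fully readable step from a starting compound with a real number. As far as these compounds go, it is also open whether an amine or a carboxylic acid at the same place would behave like methoxy.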